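Swapping the Benzodioxin Group for a Methoxyphenyl Group

The source may hold more compounds than are shown below. What is called first, only, known or untested is meant among the compounds shown, and "the series" means these compounds.

Compound 1, `O=S(=O)(NCCCNCC1COc2ccccc2O1)c1cc(C(F)(F)F)cc(C(F)(F)F)c1`, gives 3200 nM in a toxicity assay on MCF-10A cells (Homo sapiens) for inhibition, read by MTT assay, with a stated time of 72 h; on this read-out higher numbers stand for weaker inhibition of growth and lower numbers for stronger inhibition of growth.
Compound 2, `O=S(=O)(NCCCNCc1ccc(-c2ccccc2)cc1)c1cc(C(F)(F)F)cc(C(F)(F)F)c1`, gives 2800 nM in this assay.

Among the compounds with values here, compound 1 holds the highest of the two numbers measured so far, but compound 2 lies so close to it that the two values fall within the usual scatter of this assay, and no order between them can be claimed. Both compounds share the same sulfonamide core carrying two trifluoromethyl groups, and differ only in the group attached to the saturated chain carbon bound to the amine nitrogen.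

Compound 3, `COc1ccccc1CNCCCNS(=O)(=O)c1cc(C(F)(F)F)cc(C(F)(F)F)c1`, has not yet been measured in this assay. Relative to compound 1 the change is 2-methoxyphenyl in place of 2,3-dihydro-1,4-benzodioxin-2-yl on a saturated chain carbon bound to an amine nitrogen. Within the data shown here, no step between measured compounds is available to guide the expectation, and the two measured values show that a rather different group at this position left the number essentially unchanged. Compound 3 is therefore expected to show a step from compound 1 of about a 1.1-fold higher number from compound 1 to compound 3 (0.04 log units; within the scatter), which is no step beyond the scatter. Compound 3 is estimated at 3500 nM, within a range from 1500 nM to 8000 nM.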

Compound 3, concentration for 50% growth inhibition: 5500 nM
Beside the measured number, compound 3's estimate is 1.6-fold (0.20 log units) below it; the range from low to high includes it.
By their numbers in this assay, from the lowest: compounds 2, 1 and 3 (each within the scatter of the next).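

In this assay, 2-methoxyphenyl in place of 2,3-dihydro-1,4-benzodioxin-2-yl on a saturated chain carbon bound to an amine nitrogen gives a 1.7-fold higher number from compound 1 to compound 3 (0.24 log units; within the scatter). Within the data shown here, this is the first single change at this place that can be read as a step, and it shows that the six-membered non-aromatic ring with 2 hetero atoms can give way to a single aromatic ring carrying a methoxy group without a step beyond the scatter, even as the group goes from 2 hydrogen-bond acceptors to 1. Nothing available explains the size of this step, and no measurement bears on what lies behind it.

Whether a carboxylic acid or a primary amine at this place would give a step beyond the scatter stays open, since every group shown here is built around a carbon-only aromatic ring. Also open, from the compounds shown here alone, is whether a longer chain between the two nitrogens, with 2-methoxyphenyl kept in place, would leave the number as little moved.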